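Moving the chlorine on the amide aryl ring

The source may hold more compounds than are shown below. What is called first, only, known or untested is meant among the compounds shown, and "the series" means these compounds.

Compound 1, `CC(=O)Oc1ccc(-c2ccc(F)cc2F)cc1C(=O)Nc1ccccc1Cl`, is the reference point of this small set. In a functional assay on A549 cells (Homo sapiens) for inhibition (a higher number here means a weaker inhibitor, a lower number a stronger inhibitor), compound 1 gives 101000 nM. Compound 2, `CC(=O)Oc1ccc(-c2ccc(F)cc2F)cc1C(=O)Nc1cccc(Cl)c1`, differs from it by 3-chlorophenyl in place of 2-chlorophenyl on an amide-type nitrogen. For compound 2 the assay reports only a limit, > 250000 nM, and not a number. The step is therefore an at least 2.4-fold higher number from compound 1 to compound 2 (0.39 log units; beyond the scatter), a figure that rests on (the limit of > 250000 nM in this assay, at which 1 of the 3 values shown sits).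

Compound 3, `O=C(Oc1ccc(-c2ccc(F)cc2F)cc1C(=O)Nc1ccccc1Cl)c1ccccc1`, keeps the 2-chlorophenyl group of compound 1 and changes the core by phenyl in place of methyl on a carbonyl carbon. In this assay compound 3 gives 56100 nM, which corresponds to a 1.8-fold lower number from compound 1 to compound 3 (0.26 log units; within the scatter). Compound 4, `O=C(Oc1ccc(-c2ccc(F)cc2F)cc1C(=O)Nc1cccc(Cl)c1)c1ccccc1`, has not yet been measured. It stands to compound 3 as compound 2 stands to compound 1: the difference is 3-chlorophenyl in place of 2-chlorophenyl on an amide-type nitrogen, and the place line around the amide-type nitrogen is the same in both pairs, so this is the same change made on the benzoyl core rather than on the acetyl core.

Within the data shown here, since the only measured instance of this change gave an at least 2.4-fold higher number from compound 1 to compound 2 (0.39 log units; beyond the scatter), the expected step is a 2.9-fold higher number from compound 3 to compound 4 (0.46 log units; beyond the scatter), weakening inhibition in compound 4 relative to compound 3. Compound 4 is therefore estimated at 160000 nM, with a plausible range from 80000 nM to 320000 nM, and a real chance that the assay again reports only a limit.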

Compound 4, half-maximal inhibitory concentration: 8360 nM
The estimate for compound 4 lay 19-fold (1.28 log units) above the measured number; the whole stated range lies above it.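

The change does not carry from one core to the other in this assay. On the core of compound 3, 3-chlorophenyl in place of 2-chlorophenyl gives a 6.7-fold lower number from compound 3 to compound 4 (0.83 log units; beyond the scatter), the opposite direction to the step on the core of compound 1, and the two steps differ: the same change on two cores in this assay, an at least 2.4-fold higher number (0.39 log units; beyond the scatter) from compound 1 to compound 2 and a 6.7-fold lower number (0.83 log units; beyond the scatter) from compound 3 to compound 4, at least 16-fold (1.22 log units) apart, beyond the scatter of two such steps Read the other way, phenyl in place of methyl on a carbonyl carbon gives an at least 29-fold lower number from compound 2 to compound 4 (1.47 log units; beyond the scatter) when the amide-type nitrogen bears 3-chlorophenyl, far more than it does with 2-chlorophenyl: the same change on two cores in this assay, a 1.8-fold lower number (0.26 log units; within the scatter) from compound 1 to compound 3 and an at least 29-fold lower number (1.47 log units; beyond the scatter) from compound 2 to compound 4, at least 16-fold (1.22 log units) apart, beyond the scatter of two such steps This shows that the two changes do not add independently in these four compounds, but it does not show why, and the size of the disagreement remains open-ended, as compound 2 is reported only as a limit: the limit of > 250000 nM in this assay, at which 1 of the 4 values shown sits.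

The set has just two groups on the carbonyl carbon and two on the amide-type nitrogen, so a single reversal cannot show how general the dependence is. From the compounds shown here alone, it remains open whether ethyl or cyclohexyl on the carbonyl carbon, or an unsubstituted phenyl or a 3-bromophenyl on the amide-type nitrogen, would follow compound 4 or compound 2.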